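Cytotoxicity notes on an azetidine sulfonamide amide series

A few compounds are considered here, and "the series" means these few. Any claim that something is new, unique, unknown or untested is made for them only; others in the source may bear on it.

Measured so far:
- compound 1 `O=C(NO)c1ccc(N(Cc2ccc(C3CCOCC3)cc2)C(=O)[C@H]2CCN2S(=O)(=O)c2c(F)c(F)c(F)c(F)c2F)cc1`: 4300 nM
- compound 2 `CNC(=O)c1ccc(N(Cc2ccc(C3CCCCC3)cn2)C(=O)[C@H]2CCN2S(=O)(=O)c2c(F)c(F)c(F)c(F)c2F)c(F)c1`: "not determined" (no result reported)
- compound 3 `O=C([C@H]1CCN1S(=O)(=O)c1c(F)c(F)c(F)c(F)c1F)N(Cc1ccc(C2CCCCC2)cc1)c1ccc2c(=O)[nH]ncc2c1`: 4600 nM

In an ADME assay on MCF-10A cells (Homo sapiens) for cytotoxicity, with a stated time of 72 h (a lower number here means that less compound is needed, a higher number that more compound is needed for the effect), compound 1 gives 4300 nM and compound 3 gives 4600 nM; these two values lie within the usual scatter of each other, so no order between them is claimed. Compound 2 has no result in this assay, its entry reading "not determined" (no result reported), so it stands nowhere on these numbers; it is only the reference structure for the next compound.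

Compound 4 `O=C1NC(=O)c2cc(N(Cc3ccc(C4CCCCC4)cn3)C(=O)[C@H]3CCN3S(=O)(=O)c3c(F)c(F)c(F)c(F)c3F)ccc21` is the compound to be measured. It differs from compound 2 on an amide-type nitrogen: a group of 11 heavy atoms (8 carbon, 1 nitrogen, 2 oxygen; one five-membered non-aromatic ring with 1 hetero atom, one six-membered aromatic ring of carbon only) in place of a group of 11 heavy atoms (8 carbon, 1 nitrogen, 1 oxygen, 1 fluorine; one six-membered aromatic ring of carbon only), on an amide-type nitrogen. The group that leaves carries a 2-fluoro-4-(methylcarbamoyl)phenyl; the group that enters carries a five-membered non-aromatic ring with one hetero atom fused to a six-membered aromatic ring of carbon only.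

Within the data shown here, with no number for compound 2 and no measured step of this kind, the step cannot be sized in this assay; the two measured compounds, which share the rest of the scaffold, both sit in the low-micromolar range. On that basis compound 4 is expected to fall near 5000 nM in this assay, with a range of 1500 nM to 20000 nM.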

Compound 4, half-maximal effective concentration: 8100 nM
Estimate against measurement, compound 4: 1.6-fold (0.21 log units) below, within the range that was stated.
By their numbers in this assay, from the lowest: compounds 1, 3 and 4 (each within the scatter of the next).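

No step can be read from compound 2 to compound 4, as compound 2 carries no value to set against compound 4 at 8100 nM. On these data alone, whether replacing the 2-fluoro-4-(methylcarbamoyl)phenyl group on the amide-type nitrogen changes the read-out stays open. No evidence bears on this result.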